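The source may hold more compounds than are shown below. What is called first, only, known or untested is meant among the compounds shown, and "the series" means these compounds.

Measured in an ADME assay on MRC5 cells (Homo sapiens) for cytotoxicity, read by fluorescence, with a stated time of 24 h; on this read-out lower numbers stand for stronger inhibition and higher numbers for weaker inhibition:

- Compound 1 `O=C(CC1S/C(=N\N=C\c2c(-c3ccccc3)[nH]c3ccccc23)NC1=O)c1ccccc1`: > 50000 nM (a limit)
- Compound 2 `CCOC(=O)c1sc(N/N=C/c2c(-c3ccc([N+](=O)[O-])cc3)[nH]c3ccccc23)nc1C`: 23500 nM
- Compound 3 `CC(=O)OCCC1S/C(=N\N=C\c2c(-c3ccccc3)[nH]c3ccccc23)NC1=O`: 42800 nM

Only two of these are actual numbers: compound 3 at 42800 nM and compound 2 at 23500 nM lie within the scatter of each other. Compound 4 `CCC1S/C(=N\N=C\c2c(-c3ccccc3)[nH]c3ccccc23)NC1=O` carries hydrogen in place of acetoxy on a saturated chain carbon, two bonds along the chain from a saturated ring carbon. Among the compounds with values here, the one measured step that changes this chain is an at least 1.1-fold lower number from compound 1 to compound 3 (0.06 log units; that floor lies within the scatter), and it stays within the scatter. That step rests on (the limit of > 50000 nM in this assay, at which 1 of the 3 values shown sits). No step beyond the scatter is therefore expected in this assay. The estimated step is a 1.1-fold lower number from compound 3 to compound 4 (0.03 log units; within the scatter). For compound 4 the expected value is 40000 nM, with an estimated range from 20000 nM to 65000 nM.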

Compound 4, half-maximal inhibitory concentration: > 50000 nM
Compound 4 was reported as a limit; the forecaster's own chance of this, stated with the estimate: 30%; at least 1.2-fold (0.09 log units) between middle value and limit.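

In this assay, hydrogen in place of acetoxy on this chain gives an at least 1.1-fold higher number from compound 3 to compound 4 (0.06 log units; that floor lies within the scatter), and only the floor of that step is known. With 2-acetoxyethyl cut back to ethyl, compound 4 ends at a limit, as compound 1 does, so the step between those two cannot be read. The true size of the change from acetoxy to hydrogen stays hidden because of that limit: the limit of > 50000 nM in this assay, at which 2 of the 4 values shown sit.

The compounds shown leave open what an amine, a carboxylic acid or a longer chain at this position would give in this assay.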